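A few compounds are considered here, and "the series" means these few. Any claim that something is new, unique, unknown or untested is made for them only; others in the source may bear on it.

Measured so far in a functional assay on SW480 cells (Homo sapiens) for cytotoxicity, read by MTT assay, with a stated time of 24 h; a lower number here means a stronger inhibitor, a higher number a weaker inhibitor:
Compound 1 `C=CC1=C(C(=O)NCCCCC)C(c2ccc(Cl)c(Cl)c2)OC1` gives 27500 nM.
Compound 2 `C=CC1=C(C(=O)Nc2ccccc2)C(c2ccc(Cl)c(Cl)c2)OC1` gives only a limit of the assay, > 100000 nM.
Compound 3 `C=CC1=C(C(=O)Nc2ccccc2)C(c2ccc(F)cc2)OC1` likewise gives only a limit, > 100000 nM.

Two of the three values sit at the limit of > 100000 nM in this assay, at which 2 of the 3 values shown sit, so little of the series is readable. For the measured compounds named here, the one readable change, (pentyl in place of phenyl on an amide-type nitrogen), gave an at least 3.6-fold lower number from compound 2 to compound 1 (0.56 log units; beyond the scatter). The two cores differ by 4-fluorophenyl in place of 3,4-dichlorophenyl on a saturated ring carbon, and that step, a step that the two limits leave unreadable from compound 2 to compound 3, cannot be sized between two limits. Compound 4 `C=CC1=C(C(=O)NCCCCC)C(c2ccc(F)cc2)OC1` carries the same change on the core of compound 3, (pentyl in place of phenyl on an amide-type nitrogen), with the place worded identically. Only a limit is known for compound 3, so any number for compound 4 is uncertain. The step is expected as an at least 2.5-fold lower number from compound 3 to compound 4 (0.39 log units; beyond the scatter), resting on compound 1 having given 27500 nM. Compound 4 is expected near 40000 nM, between 15000 nM and 150000 nM.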

Compound 4, half-maximal inhibitory concentration: > 100000 nM
Compound 4: a limit, no number (the forecaster's own chance of this, stated with the estimate: 35%); middle value at least 2.5-fold (0.39 log units) away from the limit.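

Compound 3 and compound 4 both give only a limit, so no step can be read between them. From the compounds shown here alone, it remains open whether pentyl in place of phenyl on an amide-type nitrogen changes the number at all on the core of compound 3.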